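The source may report more compounds than this note shows. Statements on the series, on what has been measured and on what is new or still open speak of the compounds shown alone.

Compound 1 `O=C(Nc1cccc(-c2ccccn2)c1)C(Cl)Cl` carries a dichloroacetamide on a benzene ring bearing a pyridin-2-yl group. In a functional assay on A549 cells (Homo sapiens) for cytotoxicity, read by MTT assay, with a stated time of 68 h (a lower number here means a stronger inhibitor, a higher number a weaker inhibitor), compound 1 gives only a limit, > 50000 nM, with no number behind it. Among the compounds with values here, that limit, (the limit of > 50000 nM in this assay, at which 1 of the 3 values shown sits), is where compound 1 stands among the three values so far. The two bis-aryl analogues sit elsewhere: compound 2 `CSc1cccc(-c2cc(NC(=O)C(Cl)Cl)cc(-c3cccc(SC)c3)c2)c1` gives 15900 nM in this assay, and compound 3 `CC(C)Oc1ccc(-c2cc(NC(=O)C(Cl)Cl)cc(-c3ccc(OC(C)C)cc3)c2)cc1` gives 3820 nM. Compound 4 `O=C(Nc1cccc(-c2ccccc2)c1)C(Cl)Cl` is not yet measured; it differs from compound 1 by phenyl in place of pyridin-2-yl on an aromatic carbon. The expected step that the limit leaves unreadable from compound 1 to compound 4 is none beyond the scatter, since the limit for compound 1 gives no number to move from. Compound 4 is expected near 60000 nM, somewhere between 15000 nM and 250000 nM.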

Compound 4, half-maximal inhibitory concentration: 8900 nM
For compound 4 the middle estimate is 6.7-fold (0.83 log units) above the measured one, outside the stated range (below it).
By their numbers in this assay, from the lowest: compound 3; then compounds 4 and 2 (each within the scatter of the next). At a limit, above all of these: compound 1.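

In this assay, phenyl in place of pyridin-2-yl, meta to the ((dichloromethyl)carbonyl)amino group, gives an at least 5.6-fold lower number from compound 1 to compound 4 (0.74 log units; beyond the scatter). Within the data shown here, this is the first single-place change, and it shows that exchanging the ring nitrogen for carbon at this position alone moves the number beyond the scatter. The step is only a floor, and its full size cannot be read, because compound 1 stands at a limit: the limit of > 50000 nM in this assay, at which 1 of the 4 values shown sits.

Open, as far as these compounds go, is how a phenyl ring bearing an amine or a carboxylic acid at this position would compare with compound 4. Also open, from the compounds shown here alone, is whether pyridin-3-yl would stay closer to compound 1 or to compound 4.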